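Restoring an aryl group on the amide side chain

The source may report more compounds than this note shows. Statements on the series, on what has been measured and on what is new or still open speak of the compounds shown alone.

The three measured compounds share one core and differ only in the group attached to the carbonyl on the piperazine. Compound 1 `CC(C)C[C@H](N)c1cc(C(F)(F)F)ccc1N1CCN(C(=O)CSc2ccc(Cl)cc2Cl)CC1` carries a (2,4-dichlorophenyl)sulfanyl group there, and in an assay on HEK293 cells for displacement of a labelled ligand from Melanocortin receptor 4 (Homo sapiens) (a higher number here means a weaker inhibitor, a lower number a stronger inhibitor), compound 1 gives 1500 nM. Compound 2 `CC(C)C[C@H](N)c1cc(C(F)(F)F)ccc1N1CCN(C(=O)COc2cccc(Cl)c2Cl)CC1` carries 2,3-dichlorophenoxy instead, and in this assay compound 2 gives 2500 nM; the step of a 1.7-fold higher number from compound 1 to compound 2 (0.22 log units; within the scatter) lies within the scatter. Compound 3 `CC(C)C[C@H](N)c1cc(C(F)(F)F)ccc1N1CCN(C(=O)CCC(=O)N(C)C)CC1` has the (dimethylcarbamoyl)methyl group, and in this assay compound 3 reaches only the limit of > 10000 nM, so its true value is not known, only that it sits at the limit of > 10000 nM in this assay, at which 1 of the 3 values shown sits. Removing the chlorinated aryl group cost an at least 6.6-fold higher number from compound 1 to compound 3 (0.82 log units; beyond the scatter) and an at least 4.0-fold higher number from compound 2 to compound 3 (0.60 log units; beyond the scatter).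

Compound 4 `CC(C)C[C@H](N)c1cc(C(F)(F)F)ccc1N1CCN(C(=O)CCC(=O)c2ccc(Cl)cc2)CC1` differs from compound 3 in one place: 4-chlorophenyl in place of dimethylamino on a carbonyl carbon. This puts a chlorinated aromatic ring back onto the chain, as in compound 1 and compound 2, so a gain beyond the scatter is expected in this assay. The expected step is an at least 3.3-fold lower number from compound 3 to compound 4 (0.52 log units; beyond the scatter). Compound 4 is estimated at 3000 nM, with a range from 1000 nM to 10000 nM.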

Compound 4, inhibition constant: 820 nM
The estimate for compound 4 lay 3.7-fold (0.56 log units) above the measured number, outside the stated range (below it).
By their numbers in this assay, from the lowest: compounds 4, 1 and 2 (each within the scatter of the next, the first and the last beyond it). At a limit, above all of these: compound 3.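

The step from dimethylamino to 4-chlorophenyl on this carbonyl carbon is an at least 12-fold lower number from compound 3 to compound 4 (1.08 log units; beyond the scatter), which shows that an aromatic ring can restore binding here without the sulfur or oxygen link found in compound 1 and compound 2. That step can be given only as a minimum, as compound 3 has a limit and not a number: the limit of > 10000 nM in this assay, at which 1 of the 4 values shown sits. Against the earlier aryl compounds, the change gives a 1.8-fold lower number from compound 1 to compound 4 (0.26 log units; within the scatter) and a 3.0-fold lower number from compound 2 to compound 4 (0.48 log units; beyond the scatter), so the new side chain matches the first and improves on the second, though each of these steps changes the linker and the ring's chlorine pattern together.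

From the compounds shown here alone, it remains open whether the ring alone is enough or the chlorine also contributes, which a plain phenyl on this carbonyl carbon would test. Going by these compounds, how a longer chain between the two carbonyls would read is also open.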